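Anilino Analogues of a Diterpenoid Core in Cytotoxicity

The source may hold more compounds than are shown below. What is called first, only, known or untested is meant among the compounds shown, and "the series" means these compounds.

This account follows three measured compounds and one still untested. Compound 1 `C=C1[C@@H](OC(C)=O)C[C@@H]2[C@](C)(COC=O)[C@H](OC(C)=O)CC[C@@]2(C)[C@@H]1C[C@@H](Nc1ccc(Br)cc1)C1=CCOC1=O` carries a 4-bromophenylamino group on its side chain; compound 2 `C=C1[C@@H](OC(C)=O)C[C@@H]2[C@](C)(CO[Si](C)(C)C(C)(C)C)[C@H](OC(C)=O)CC[C@@]2(C)[C@@H]1C[C@@H](Nc1cccc(F)c1)C1=CCOC1=O` and compound 3 `C=C1CC[C@@H]2[C@](C)(CO[Si](C)(C)C(C)(C)C)[C@H](OC(C)=O)CC[C@@]2(C)[C@@H]1C/C=C1/C(=O)OC[C@H]1OC(C)=O` share much of the same core but differ at several places at once, so no single-point step can be read between them. In a functional assay on A549 cells (Homo sapiens) for cytotoxicity, read by sulforhodamine B assay (on this read-out higher numbers stand for weaker inhibition and lower numbers for stronger inhibition), compound 1 gives 15900 nM, the highest of the three numbers, and thus the weakest inhibition seen here. Compound 2 gives 4060 nM and compound 3 gives 3990 nM, both beyond the scatter below compound 1, while the two of them sit within the scatter of each other.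

Compound 4 `C=C1[C@@H](OC(C)=O)C[C@@H]2[C@](C)(COC=O)[C@H](OC(C)=O)CC[C@@]2(C)[C@@H]1C[C@@H](Nc1cccc2ccccc12)C1=CCOC1=O` is the untested analogue. It differs from compound 1 in one place: naphthalen-1-yl in place of 4-bromophenyl on an amine nitrogen. Among the measured compounds shown here, no measured pair isolates this change, so its size cannot be read from the data. The expectation is a small step, and the step of a 1.4-fold lower number from compound 1 to compound 4 (0.16 log units; within the scatter) is estimated to lie within the scatter, with a slight lean toward a lower number. Compound 4 is therefore expected to give 11000 nM in this assay, with a range from 3500 nM to 35000 nM.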

Compound 4, half-maximal inhibitory concentration: 35600 nM
For compound 4 the middle estimate is 3.2-fold (0.51 log units) below the measured one; the whole stated range lies below it.
By their numbers in this assay, from the lowest: compounds 3 and 2 (each within the scatter of the next); then compound 1; then compound 4.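

In this assay, among the compounds shown here, putting naphthalen-1-yl in place of 4-bromophenyl on the amine nitrogen gives a 2.2-fold higher number from compound 1 to compound 4 (0.35 log units; beyond the scatter), a modest step toward weaker inhibition and the only step in this set that isolates a single change. For the compounds shown here, it shows what the earlier compounds could not: the group on this nitrogen is not indifferent, since exchanging one aromatic ring carrying a bromine for two fused aromatic rings of carbon only moves the number beyond the scatter, and upward rather than downward. No measurement at hand explains why this exchange weakens inhibition.

The step combines two differences, the loss of the bromine and the gain of a second aromatic ring, and the compounds shown leave open which of them carries it, a question on which a plain phenyl or a naphthalen-2-yl on the same nitrogen would bear. Going by these compounds alone, compound 2 and compound 3 differ from compound 1 and compound 4 in several places, so no steps to them can be read, and it remains open whether the same exchange would have a similar size on the core of compound 2.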